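The source may hold more compounds than are shown below. What is called first, only, known or untested is meant among the compounds shown, and "the series" means these compounds.

Readings so far in an ADME assay on RAW264.7 cells (Mus musculus) for cytotoxicity, read by MTT assay; a higher number here means a weaker inhibitor, a lower number a stronger inhibitor

compound 1 `COc1ccc(C(=O)/C=C/C=C/c2ccccc2)cc1` gives > 100000 nM (a limit of the assay, not a number)
compound 2 `COc1ccc(/C=C/C=C/C(=O)c2ccc(OC)cc2)cc1` gives "not determined" (no result reported)
compound 3 `O=C(/C=C/C=C/c1ccc(Cl)cc1)c1ccc(Cl)cc1` gives "not determined" (no result reported)

Compound 3 has no number to stand on, as its entry in this assay reads "not determined" (no result reported). Compound 2 offers no number either. Within the data shown here, the only reading is a limit, held by compound 1 (the limit of > 100000 nM in this assay, at which 1 of the 3 values shown sits).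

The next compound to be read is compound 4 `COc1ccc(C(=O)/C=C/C=C/c2ccc(Cl)cc2)cc1`. The change is methoxy in place of chloro on an aromatic carbon, para to a large group. Among the measured compounds shown here, no step between measured compounds exists to size this change, and compound 3 gives no starting number. For the measured compounds named here, the only guide is compound 1 with > 100000 nM, which is a limit. Compound 4 is therefore expected to read close to compound 1 in this assay, with no step beyond the scatter in either direction, and quite possibly to return a limit as well. For compound 4 the estimated value is 100000 nM, with an expected range from 35000 nM to 200000 nM.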

Compound 4, half-maximal inhibitory concentration: 80200 nM
Estimate against measurement, compound 4: 1.2-fold (0.10 log units) above; the measured number falls inside the stated range.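

In this assay, among these compounds, compound 4 gives 80200 nM, the first reading that is a number and not a limit. Chloro in place of hydrogen on an aromatic carbon comes with an at least 1.2-fold lower number from compound 1 to compound 4 (0.09 log units; that floor lies within the scatter), so the change is not shown to act beyond the scatter, though only a floor can be read. The reading for compound 1 is a limit, which leaves the true size of this step open: the limit of > 100000 nM in this assay, at which 1 of the 4 values shown sits.

Compound 3 has no result in this assay, so the size of methoxy in place of chloro at this position, para to a large group, cannot be read. As far as these compounds go, how an amine or a carboxylic acid on this aromatic carbon would read in this assay remains open, as does whether any other group here gives a clear step from compound 4.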